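Changing the benzyl group of compound 2

A few compounds are considered here, and "the series" means these few. Any claim that something is new, unique, unknown or untested is made for them only; others in the source may bear on it.

Compound 1 `CCc1nc2c(C)cc(-c3ccc(CN4CCC(O)CC4)cc3)cn2c1NC(=O)OCc1cc(Cl)cc(Cl)c1` gives 4580 nM in a functional assay on RAW264.7 cells (Mus musculus) for inhibition, read by MTT assay, with a stated time of 72 h; on this read-out lower numbers stand for stronger inhibition and higher numbers for weaker inhibition. Compound 2 `CCc1nc2c(C)cc(-c3ccc(CN4CCC[C@H]4CO)cc3)cn2c1NC(=O)OCc1cc(Cl)cc(Cl)c1` gives 2510 nM, which leaves it level with compound 1: a 1.8-fold lower number from compound 1 to compound 2 (0.26 log units; within the scatter). Compound 3 `CCc1nc2c(C)cc(-c3ccc(CN4CCC[C@H]4CO)cc3)cn2c1NC(=O)OCc1ccc(F)cc1` differs from compound 2 at one place, on a saturated chain carbon bound to an oxygen next to a carbonyl group: 4-fluorophenyl in place of 3,5-dichlorophenyl on a saturated chain carbon bound to an oxygen next to a carbonyl group. Among the measured compounds shown here, the sole measured step, a 1.8-fold lower number from compound 1 to compound 2 (0.26 log units; within the scatter), lies at another place and does not bear on this change. No step beyond the scatter is therefore expected, and the estimated step is a 1.8-fold higher number from compound 2 to compound 3 (0.25 log units; within the scatter). The expected value for compound 3 is 4500 nM, within an estimated range of 1500 nM to 13000 nM.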

Compound 3, half-maximal inhibitory concentration: > 20000 nM
Compound 3 gave a limit, no number; the forecaster's own chance of this, stated with the estimate: 10%; middle value at least 4.4-fold (0.64 log units) away from the limit.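

The benzyl group proves sensitive where the earlier change was not: 4-fluorobenzyl in place of 3,5-dichlorobenzyl gives an at least 7.9-fold higher number from compound 2 to compound 3 (0.90 log units; beyond the scatter). Among the compounds shown here, the only earlier step, a 1.8-fold lower number from compound 1 to compound 2 (0.26 log units; within the scatter), lay at another place and stayed within the scatter. Compound 3 gave only a limit, not a number: the limit of > 20000 nM in this assay, at which 1 of the 3 values shown sits.

The compounds shown leave open which part of this exchange carries the loss, the departure of the two chlorine atoms or the entry of fluorine. A 4-chlorobenzyl or 3,5-difluorobenzyl group would separate the two.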